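The source may hold more compounds than are shown below. What is called first, only, known or untested is meant among the compounds shown, and "the series" means these compounds.

Measured so far:
compound 1 `CCCN(CCC)Cc1ccc(Cl)c(-c2ccccc2OC)c1` — "not active" (no number reported)
compound 2 `CCNCc1ccc(Cl)c(-c2ccccc2OC)c1` — 71%

Among the measured compounds shown here, in a functional assay on HEK293 cells for agonist activity at 5-hydroxytryptamine receptor 7 (Homo sapiens), read by cAMP accumulation, with a stated time of 30 min (a higher number here means a larger maximal response, a lower number a smaller maximal response), compound 2 gives 71%, the only number; compound 1 is recorded as "not active" (no number reported) without a number. Compound 3 `COc1ccccc1-c1cc(CN(C)C)ccc1Cl` differs from compound 2 by dimethylamino in place of ethylamino on a saturated chain carbon bound to an aromatic carbon. For the measured compounds named here, no step between measured compounds is available, so the expectation rests on compound 1 and compound 2 alone. The step from compound 2 to compound 3 is expected to be a drop beyond the scatter, a number 21 percentage points lower from compound 2 to compound 3 (beyond the scatter), though a numbered result still seems likely. Compound 3 is estimated at 50%, within 15% to 80%.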

Compound 3, largest response reached (Emax), in percent of the reference or control that the assay uses: 11%
The estimate for compound 3 lay 39 percentage points above the measured number; the whole stated range lies above it.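

In this assay, the amine on the saturated chain carbon bound to an aromatic carbon proves highly sensitive: with the heavy-atom count unchanged, dimethylamino in place of ethylamino gives a number 60 percentage points lower from compound 2 to compound 3 (beyond the scatter). The change also takes the count of hydrogen-bond donors in this group from one to none, but that difference is not separated from the others between the two groups. Nothing available explains the drop.

Open, on these data alone, is whether methylamino, which keeps a hydrogen-bond donor, holds the response of compound 2. Also open, as far as these compounds go, is how diethylamino or a pyrrolidine ring at this place would read in this assay.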